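Bromo-to-methyl exchange on a second anilide core

This account rests on a few compounds, and the source may have more. Where it says the series, first, only, none or still open, it means among the compounds named here.

Measured so far in a functional assay on cells (Splenocyte, Mus musculus, strain BALB/c) for inhibition, read by MTT assay, with a stated time of 48 h; a higher number here means a weaker inhibitor, a lower number a stronger inhibitor:
compound 1, `CO/C(=C\c1ccc(Cl)cc1)C(=O)Nc1ccc(Br)cc1`, gives 11000 nM;
compound 2, `CO/C(=C\c1ccc(Cl)cc1)C(=O)Nc1ccc(C)cc1`, gives 12700 nM;
compound 3, `CO/C(=C\c1ccc(OC)cc1)C(=O)Nc1ccc(Br)cc1`, gives 1770 nM.

Compound 4, `CO/C(=C\c1ccc(OC)cc1)C(=O)Nc1ccc(C)cc1`, is not yet measured. It differs from compound 3 by methyl in place of bromo on an aromatic carbon. The same change has been made once before, from compound 1 to compound 2: methyl in place of bromo on an aromatic carbon, giving a 1.2-fold higher number from compound 1 to compound 2 (0.06 log units; within the scatter). The two cores differ by methoxy in place of chloro on an aromatic carbon, a change that produced a 6.2-fold lower number from compound 1 to compound 3 (0.79 log units; beyond the scatter).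

Since the earlier step stayed within the scatter, compound 4 is expected to land close to compound 3, with an estimated step of a 1.2-fold higher number from compound 3 to compound 4 (0.07 log units; within the scatter). Compound 4 is therefore estimated at 2100 nM in this assay, expected to fall between 900 nM and 5000 nM. Among the measured compounds shown here, this rests only on the one prior instance of the change and on the value of compound 3.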

Compound 4, half-maximal inhibitory concentration: 940 nM
The estimate for compound 4 lay 2.2-fold (0.35 log units) above the measured number; low and high end bracket the measured number.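

In this assay methyl in place of bromo gave a 1.9-fold lower number from compound 3 to compound 4 (0.27 log units; within the scatter) and this agrees with the same change on the other core: the same change on two cores in this assay, a 1.2-fold higher number (0.06 log units; within the scatter) from compound 1 to compound 2 and a 1.9-fold lower number (0.27 log units; within the scatter) from compound 3 to compound 4, 2.2-fold (0.34 log units) apart, within the scatter of two such steps. Methoxy in place of chloro gave a 14-fold lower number from compound 2 to compound 4 (1.13 log units; beyond the scatter) and this likewise agrees with its earlier step: the same change on two cores in this assay, a 6.2-fold lower number (0.79 log units; beyond the scatter) from compound 1 to compound 3 and a 14-fold lower number (1.13 log units; beyond the scatter) from compound 2 to compound 4, 2.2-fold (0.34 log units) apart, within the scatter of two such steps. Across these four compounds, each change therefore carried from one core to the other with no difference beyond the scatter, but two cores do not show that either change would carry to a further core, nor do they explain why these steps agree.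

The compounds shown leave open how other groups would behave in these places, such as an amine or a carboxylic acid in place of the methyl. On these data alone, a longer chain in place of the methoxy also remains untested here.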